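Replacing the Phenyl Amide with a Trifluoropropyl Chain

A few compounds are considered here, and "the series" means these few. Any claim that something is new, unique, unknown or untested is made for them only; others in the source may bear on it.

Three glucose-derived compounds have been examined in an assay on isolated protein (Sus scrofa) for inhibition of glycogen phosphorylase, brain form (Homo sapiens); on this read-out higher numbers stand for weaker inhibition and lower numbers for stronger inhibition. Compound 1, `N#CC[C@]1(O)O[C@H](CO)[C@@H](O)[C@H](O)[C@H]1O`, gives 7940000 nM. Compound 2, `O=C(Nc1ccccc1)[C@H]1O[C@H](CO)[C@@H](O)[C@H](O)[C@H]1O`, gives 12600000 nM, and compound 3, `O=C(Nc1ccccc1)[C@@H]1O[C@H](CO)[C@@H](O)[C@H](O)[C@H]1O`, gives 5010000 nM. Compound 3 therefore holds the lowest number of the three, although its gap to compound 1 lies within the scatter, so only its separation from compound 2 can be taken as real. For the measured compounds named here, the one measured step, a 2.5-fold lower number from compound 2 to compound 3 (0.40 log units; beyond the scatter), rests on the fact that compounds 2 and 3 differ only in the configuration as drawn alone.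

Compound 4, `O=C(NCCC(F)(F)F)[C@@H]1O[C@H](CO)[C@@H](O)[C@H](O)[C@H]1O`, is the next compound to be measured. It differs from compound 3 by 3,3,3-trifluoropropyl in place of phenyl on an amide-type nitrogen. Going by the values given here, none of the measured steps touches the group on the amide nitrogen: the single step, from compound 2 to compound 3, concerns configuration only, and all three measured compounds carry either the phenyl amide or no amide at all. There is thus no measured guide for the effect of exchanging phenyl for 3,3,3-trifluoropropyl in this assay. All three numbers sit close together at very weak inhibition, and a change on the amide nitrogen is expected to move compound 4 only modestly, if at all, with a somewhat higher number considered a little more likely than a lower one. Compound 4 is therefore estimated at 8000000 nM, within a range of 2000000 nM to 30000000 nM, corresponding to an expected step of a 1.6-fold higher number from compound 3 to compound 4 (0.20 log units; within the scatter).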

Compound 4, inhibition constant: 7940000 nM
For compound 4 the middle estimate is 1.0-fold (0.00 log units) above the measured one; measured number inside the range.
By their numbers in this assay, from the lowest: compounds 3, 1, 4 and 2 (each within the scatter of the next, the first and the last beyond it).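

In this assay, for the compounds shown here, the group on the amide nitrogen now has its first reading, and the exchange of phenyl for 3,3,3-trifluoropropyl gives (a 1.6-fold higher number from compound 3 to compound 4 (0.20 log units; within the scatter)), whereas the only earlier step concerned configuration alone. Compounds 3 and 4 therefore cannot be told apart at this position, even though the six-membered aromatic ring of carbon only leaves and a group with no ring enters, so on the configuration of compound 3 the aromatic ring makes no readable difference to this very weak inhibition. Nothing in the evidence at hand explains this result.

The compounds shown leave open whether 3,3,3-trifluoropropyl and phenyl would also read alike on the opposite configuration, that of compound 2, and whether the fluorine atoms matter at all, which a plain propyl chain in the same place would show. They also leave open whether any group on this nitrogen can move the number beyond the scatter, for instance a longer chain, a chain ending in an amine or a carboxylic acid, or a phenyl ring carrying a hydroxyl group.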